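Fluoro for hydrogen in a triazole cytotoxicity series

This account rests on a few compounds, and the source may have more. Where it says the series, first, only, none or still open, it means among the compounds named here.

Compound 1 `CC[C@@H](CCn1cncn1)c1ccccc1`, compound 2 `CC[C@@H](CCn1cncn1)c1ccc(F)cc1` and compound 3 `CCC[C@H](CCn1cncn1)c1ccccc1` have been run in an ADME assay on HEp-2 cells (Homo sapiens) for cytotoxicity, read by MTT assay, with a stated time of 3 days; on this read-out higher numbers stand for lower toxicity in this test and lower numbers for higher toxicity in this test. Compound 1 gives 89.9 ug/mL, compound 2 gives 90.3 ug/mL and compound 3 gives 58.4 ug/mL; all three lie within the scatter of one another, so no order among them is claimed. The change from compound 1 to compound 2 is fluoro in place of hydrogen on an aromatic carbon, and it made a 1.0-fold higher number from compound 1 to compound 2 (0.00 log units; within the scatter). The difference between the core of compound 1 and the core of compound 3 is not broken down here. Compound 4 `CCC[C@H](CCn1cncn1)c1ccc(F)cc1` stands to compound 3 as compound 2 stands to compound 1: fluoro in place of hydrogen on an aromatic carbon, the same change at a place described in the same words. For compound 4 in this assay a step of about a 1.0-fold higher number from compound 3 to compound 4 (0.01 log units; within the scatter) is expected, because the same change gave a 1.0-fold higher number from compound 1 to compound 2 (0.00 log units; within the scatter). Compound 4 is accordingly estimated at 60 ug/mL, with a range from 35 ug/mL to 105 ug/mL.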

Compound 4, half-maximal cytotoxic concentration: 39.3 ug/mL
The estimate for compound 4 lay 1.5-fold (0.18 log units) above the measured number, within the range that was stated.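

In this assay, fluoro in place of hydrogen on an aromatic carbon gave a 1.5-fold lower number from compound 3 to compound 4 (0.17 log units; within the scatter). On these two cores the change carries over with no difference that can be told from the scatter: the same change on two cores in this assay, a 1.0-fold higher number (0.00 log units; within the scatter) from compound 1 to compound 2 and a 1.5-fold lower number (0.17 log units; within the scatter) from compound 3 to compound 4, 1.5-fold (0.17 log units) apart, within the scatter of two such steps

Neither step stands clear of the scatter, so the two pairs show no effect of the change on either core that needs carrying over; they do not show how it would behave on any other core. Open, on these data alone, is whether chloro, methoxy or trifluoromethyl at the same place would give a step beyond the scatter. Also open, as far as these compounds go, is how the fluoro step would read on a core with a longer chain or an amine.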